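Dithiocarbamate-linked benzamides: aryl change on piperazine

The source may hold more compounds than are shown below. What is called first, only, known or untested is meant among the compounds shown, and "the series" means these compounds.

Measured so far:
compound 1 `Nc1ccccc1NC(=O)c1ccc(CSC(=S)N2CCN(C(c3ccccc3)c3ccccc3)CC2)cc1` gives 8%
compound 2 `Nc1ccccc1NC(=O)c1ccc(CSC(=S)N2CCN(c3cccnc3)CC2)cc1` gives 66.2%

For the measured compounds named here, in a functional assay on HeLa cells (Homo sapiens) for antiproliferative activity, read by CCK-8 assay, with a stated time of 72 h, tested at 2 uM (a lower number here means a weaker effect, a higher number a stronger effect of the compound at the concentration tested), compound 2 stands highest of the two numbers known. Its nearest neighbour is compound 1, which lies far lower, and the gap between the two is beyond the usual scatter. Going by the values given here, no step between compounds that differ in one place only has been measured, so the effect of a single change on the ring amine nitrogen is not yet known.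

Compound 3 `Cc1ccc(N2CCN(C(=S)SCc3ccc(C(=O)Nc4ccccc4N)cc3)CC2)cc1` is not yet measured. It differs from compound 2 as follows: 4-methylphenyl in place of pyridin-3-yl on an amine nitrogen in a ring

For this change a modest step downward is expected, as a number 16.2 percentage points lower from compound 2 to compound 3 (beyond the scatter), since only compound 2 with 66.2% and compound 1 with 8% frame what a group on this nitrogen can do. Compound 3 is expected to give 50%, within a range from 20% to 75%.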

Compound 3, a percentage reported as inhibition, at one concentration (the size of the read-out at that concentration, not a potency): 25.3%
Beside the measured number, compound 3's estimate is 24.7 percentage points above it; low and high end bracket the measured number.
By their numbers in this assay, from the lowest: compound 1; then compound 3; then compound 2.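

In this assay, for the compounds shown here, the one step with a single change reads a number 40.9 percentage points lower from compound 2 to compound 3 (beyond the scatter) and counts as large, so the outcome at this amine nitrogen in a ring depends strongly on which six-membered aromatic ring it carries. A ring of carbon only is therefore not interchangeable here with one holding a hetero atom, at least for this pair. The change, however, removes the ring nitrogen of pyridin-3-yl and adds the methyl of 4-methylphenyl together, so this step alone cannot divide the loss between the two. No measurement on hand bears on the cause of the drop.

The compounds shown leave open how an unsubstituted phenyl would read, which would separate the methyl from the ring nitrogen. Also open, on these data alone, are pyridin-2-yl and pyridin-4-yl, which would show whether the place of that nitrogen matters.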